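The compounds below may be only part of what the source reports. "The series", "measured", "known", "first", "only" and "open" are said of these compounds alone.

For the measured compounds named here, in a functional assay on BAEC cells (Bos taurus) for antiproliferative activity, read by cell counting, with a stated time of 4 days (a lower number here means a stronger inhibitor, a higher number a weaker inhibitor), compound 3 `CCOC(=O)C(=O)N(Cc1cc(F)cc(F)c1)c1ccc2c(c1)OC(C)(CO)CN2C` gives 60000 nM, the only true number in the set. Compound 1 `CCOC(=O)C(=O)N(Cc1ccccc1)c1ccc2c(c1)OC(C)(CO)CN2C` reads > 100000 nM, which is a limit of the assay. Compound 2 `CN1CC(C)(CO)Oc2cc(N(Cc3ccccc3)C(=O)C(=O)O)ccc21` reads > 100000 nM, also a limit. Compound 4 `CN1CC(C)(CO)Oc2cc(N(Cc3cc(F)cc(F)c3)C(=O)C(=O)O)ccc21` differs from compound 3 by hydrogen in place of ethyl on an oxygen next to a carbonyl group. The same change was measured once, as a step that the two limits leave unreadable from compound 1 to compound 2, so it offers no size and shows no gain. The other measured step, an at least 1.6-fold lower number from compound 1 to compound 3 (0.22 log units; that floor lies within the scatter), is a different change and does not bear on this one. A reading for compound 4 at the same limit as compound 1 and compound 2 is quite possible. The expected change is small, a 1.3-fold higher number from compound 3 to compound 4 (0.12 log units; within the scatter), with no step beyond the scatter anticipated and any drift toward a higher number. For compound 4 the estimated value is 80000 nM, with an expected range of 30000 nM to 200000 nM.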

Compound 4, half-maximal inhibitory concentration: > 100000 nM
Compound 4 was reported as a limit; the forecaster's own chance of this, stated with the estimate: 55%; middle value at least 1.2-fold (0.09 log units) away from the limit.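

In this assay, hydrogen in place of ethyl on an oxygen next to a carbonyl group now has a step with a readable floor, an at least 1.6-fold higher number from compound 3 to compound 4 (0.22 log units; that floor lies within the scatter), whereas compound 1 and compound 2 gave no size for this change. With the 3,5-difluorophenyl group present, the ethoxycarbonyl to carboxy change shows no gain, though that floor stays within the scatter and the reading for compound 4 is a limit. The remaining steps cannot be read, and the series is largely held at one ceiling: the limit of > 100000 nM in this assay, at which 3 of the 4 values shown sit.

Left open is whether a methyl ester or a primary amide in place of the ethyl ester would bring a reading off that limit. Also open, on these data alone, is what chlorine or methoxy groups in place of the fluorines would do.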